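The compounds below may be only part of what the source reports. "The series", "measured", "known", "first", "only" and "open" are said of these compounds alone.

Among the compounds with values here, in a functional assay on A549 cells (Homo sapiens) for cytotoxicity, read by MTT assay, with a stated time of 72 h (on this read-out higher numbers stand for weaker inhibition and lower numbers for stronger inhibition), compound 3 (`Cn1ccc2c(Oc3ccc(NC(=O)c4cc5cccnc5n(-c5ccc(F)cc5)c4=O)cc3F)ncnc21`) gives 7320 nM, the lower of the two numbers available so far. Compound 1 (`Cn1ccc2c(Oc3ccc(NC(=O)c4cc5cccnc5n(-c5ccc(C(F)(F)F)cc5Cl)c4=O)cc3)ncnc21`) gives 364000 nM, a much higher number and a gap well beyond the usual scatter. Compound 2 (`Cn1ccc2c(Oc3ccc(NC(=O)c4cc5cccnc5n(-c5ccc(C(F)(F)F)c(Cl)c5)c4=O)cc3)ncnc21`) is reported as "not active" (no number reported), so it has no number to compare.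

The next molecule, compound 4 (`Cn1ccc2c(Oc3ccc(NC(=O)c4cc5cccnc5n(-c5ccc(C(F)(F)F)c(Cl)c5)c4=O)cc3F)ncnc21`), is compound 3 with 3-chloro-4-(trifluoromethyl)phenyl in place of 4-fluorophenyl on an aromatic nitrogen. Within the data shown here, no pair of measured compounds isolates this change, so any forecast is rough. The entering group also appears on compound 2, which gave "not active" (no number reported), and that points toward weaker inhibition. Compound 1, which carries a related group, gives 364000 nM and points the same way.

The estimated step is a 4.1-fold higher number from compound 3 to compound 4 (0.61 log units; beyond the scatter), expected to go toward a higher number and beyond the scatter. Compound 4 is expected to give about 30000 nM, with an estimated range of 6000 nM to 150000 nM.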

Compound 4, half-maximal inhibitory concentration: 320000 nM
The estimate for compound 4 lay 11-fold (1.03 log units) below the measured number; the measured number lies above the stated range.
By their numbers in this assay, from the lowest: compound 3; then compounds 4 and 1 (each within the scatter of the next).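

Within the data shown here, on the aromatic nitrogen, putting 3-chloro-4-(trifluoromethyl)phenyl in place of 4-fluorophenyl gives, in this assay, a 44-fold higher number from compound 3 to compound 4 (1.64 log units; beyond the scatter) and this is the first measured step at this position. The rest of the molecule stays the same across this pair, so the group on this nitrogen alone can move the read-out far beyond the scatter, toward much weaker inhibition. Nothing measured here explains the size of this step.

The chlorine and the trifluoromethyl enter together, so the compounds shown cannot say how much of the loss belongs to each. Also open, on these data alone, is how a plain phenyl, a 4-chlorophenyl or a phenyl carrying an amine would behave on this nitrogen.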